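Sulfonyl for Benzyl on the Ring Nitrogen: Cytotoxicity Outlook

A few compounds are considered here, and "the series" means these few. Any claim that something is new, unique, unknown or untested is made for them only; others in the source may bear on it.

Measured so far in an ADME assay on MT4 cells (Homo sapiens) for cytotoxicity; a lower number here means that less compound is tolerated, a higher number that more compound is tolerated:
Compound 1 `Cc1cc(C)cc(Cn2c(SCC(=O)Nc3ccccc3[N+](=O)[O-])nc3ccccc32)c1` gives 194000 nM.
Compound 2 `Cc1cc(C)cc(S(=O)(=O)n2c(SCC(=O)Nc3ccccc3[N+](=O)[O-])nc3ccccc32)c1` gives only a limit of the assay, >= 26000 nM.
Compound 3 `Cc1cc(C)cc(Cn2c(SCC(=O)Nc3ccc(S(N)(=O)=O)cc3Cl)nc3ccccc32)c1` gives 111000 nM.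

Compound 4 `Cc1cc(C)cc(S(=O)(=O)n2c(SCC(=O)Nc3ccc(S(N)(=O)=O)cc3Cl)nc3ccccc32)c1` is not yet measured. It comes from compound 3 by the change ((3,5-dimethylphenyl)sulfonyl in place of 3,5-dimethylbenzyl on an aromatic nitrogen). The same change, word for word in its place, turns compound 1 into compound 2: (3,5-dimethylphenyl)sulfonyl in place of 3,5-dimethylbenzyl on an aromatic nitrogen. Its measured size is a step that the limit leaves unreadable from compound 1 to compound 2, since compound 2 sits on the limit of >= 26000 nM in this assay, at which 1 of the 3 values shown sits, and the step cannot be sized. The two starting cores differ by 2-chloro-4-sulfamoylphenyl in place of 2-nitrophenyl on an amide-type nitrogen, a step of a 1.7-fold lower number from compound 1 to compound 3 (0.24 log units; within the scatter).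

Within the data shown here, with only one earlier example of the change, and that one ending at a limit, the expectation for the step from compound 3 to compound 4 in this assay rests on the direction the limit allows: the step is estimated at a 1.9-fold lower number from compound 3 to compound 4 (0.27 log units; within the scatter). Compound 4 is therefore expected at about 60000 nM, with a plausible range from 20000 nM to 180000 nM, and a real chance that only a limit is reported again.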

Compound 4, half-maximal cytotoxic concentration: 25600 nM
Estimate against measurement, compound 4: 2.3-fold (0.37 log units) above, and the stated range covers the measured number.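

In this assay, putting (3,5-dimethylphenyl)sulfonyl in place of 3,5-dimethylbenzyl gives a 4.3-fold lower number from compound 3 to compound 4 (0.64 log units; beyond the scatter), so on this core the change has a size that can be read. Compound 2 gives only a limit of the assay, >= 26000 nM, so the matching step from compound 1 cannot be read, and nothing here shows that the size of the change carries from one core to the other. The other change, 2-chloro-4-sulfamoylphenyl in place of 2-nitrophenyl, gives an at least 1.0-fold lower number from compound 2 to compound 4 (0.00 log units; that floor lies within the scatter). This change can be set side by side on two cores, yet that comparison stays unsettled too: the same change on two cores in this assay, a 1.7-fold lower number (0.24 log units; within the scatter) from compound 1 to compound 3 and an at least 1.0-fold lower number (0.00 log units; that floor lies within the scatter) from compound 2 to compound 4; the limit leaves it open whether they differ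

The compounds shown leave open whether a carbonyl link in place of the sulfonyl would give a similar number in this assay. They also leave open how the sulfonyl change behaves with other groups on the amide-type nitrogen, such as a pyridine ring or a phenyl ring bearing a carboxylic acid.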